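The source may report more compounds than this note shows. Statements on the series, on what has been measured and on what is new or still open speak of the compounds shown alone.

Measured in a functional assay on HCC827 cells (Homo sapiens) for inhibition, read by fluorescence, with a stated time of 72 h (on this read-out higher numbers stand for weaker inhibition of growth and lower numbers for stronger inhibition of growth), so far:
- compound 1 `COc1ccc(Nc2nc(N[C@H]3CC[C@H](N)CC3)nc3c2ncn3CCC(C)C)c(OC)c1`: 32900 nM
- compound 2 `N[C@H]1CC[C@H](Nc2nc(Nc3ccc(O)cc3)c3ncn(C4CCCCC4)c3n2)CC1`: 32500 nM
- compound 3 `CC(C)CCn1cnc2c(Nc3cccc(Cl)c3)nc(N[C@H]3CC[C@H](N)CC3)nc21`: 10300 nM

Compound 3 has the lowest of these three numbers, though all three are high. The next change leads to compound 4 `CC(C)CCn1cnc2c(Nc3ccc(O)cc3)nc(N[C@H]3CC[C@H](N)CC3)nc21` and puts 4-hydroxyphenyl in place of 3-chlorophenyl on a nitrogen on an aromatic ring, with the rest of compound 3 unchanged. Counted, the difference reads 4-hydroxyphenyl in place of 3-chlorophenyl on a nitrogen on an aromatic ring and adds a hydrogen-bond donor and acceptor while removing the chlorine.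

For the measured compounds named here, only one measured step alters the group at this place, and it is modest and beyond the scatter: a 3.2-fold lower number from compound 1 to compound 3 (0.50 log units; beyond the scatter). It shows that this position can move the number, but it says nothing about a hydroxyl group. The closest evidence for that is compound 2, which carries the same 4-hydroxyphenyl group on a core that differs elsewhere and stands at 32500 nM in this assay. On that basis a modest move towards a higher number, meaning weaker inhibition of growth, is expected rather than a gain.

The expected change is a 1.9-fold higher number from compound 3 to compound 4 (0.29 log units; within the scatter) in this assay. The estimated value for compound 4 is 20000 nM (expected range 8000 nM to 50000 nM).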

Compound 4, concentration for 50% growth inhibition: 14400 nM
The estimate for compound 4 lay 1.4-fold (0.14 log units) above the measured number; low and high end bracket the measured number.
By their numbers in this assay, from the lowest: compounds 3 and 4 (each within the scatter of the next); then compounds 2 and 1 (each within the scatter of the next).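

In this assay, the step that puts 4-hydroxyphenyl in place of 3-chlorophenyl on the nitrogen gives a 1.4-fold higher number from compound 3 to compound 4 (0.15 log units; within the scatter), so this assay does not separate the two groups, even though the new group brings a hydrogen-bond donor and acceptor that the old one lacks. Replacing 2,4-dimethoxyphenyl at the same place with 4-hydroxyphenyl gives a 2.3-fold lower number from compound 1 to compound 4 (0.36 log units; beyond the scatter), so two quite different groups now both give lower numbers than 2,4-dimethoxyphenyl on this core. For the compounds shown here, the new compound also gives a first reading at the other place, on the aromatic nitrogen, where isopentyl in place of cyclohexyl gives a 2.3-fold lower number from compound 2 to compound 4 (0.35 log units; beyond the scatter), which shows that the high number of compound 2 cannot be pinned on 4-hydroxyphenyl alone.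

Nothing in the data explains any of these steps. On these data alone, all four numbers remain high, so it stays open whether a 4-aminophenyl or 4-carboxyphenyl group on the nitrogen, or a longer chain in place of isopentyl, would bring the number down by much more.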